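Swapping Carbamoyl for 4-Aminophenyl on a Shared Core

A few compounds are considered here, and "the series" means these few. Any claim that something is new, unique, unknown or untested is made for them only; others in the source may bear on it.

Compound 1 `Cc1ccc(-c2ccc(NC3=CC(=O)c4ncncc4C3=O)cc2F)cc1`: 5000 nM
Compound 2 `NC(=O)c1ccc(NC2=CC(=O)c3ncncc3C2=O)cc1`: > 10000 nM, a limit of the assay, not a number
Compound 3 `COc1cc(NC2=CC(=O)c3ncncc3C2=O)cc(OC)c1`: 16300 nM

These three share one core and differ only in the group carried on the aromatic ring attached to the amine. In a functional assay on BXPC-3 cells (Homo sapiens) for cytotoxicity, read by MTT assay, with a stated time of 72 h (on this read-out higher numbers stand for weaker inhibition and lower numbers for stronger inhibition), compound 1 gives 5000 nM. Compound 3 gives 16300 nM. For compound 2 the assay reports only a limit, > 10000 nM. Compound 2 therefore stands at the weak end of the numbers shown, at the limit of > 10000 nM in this assay, at which 1 of the 3 values shown sits. Compound 4 `Nc1ccc(-c2ccc(NC3=CC(=O)c4ncncc4C3=O)cc2)cc1` has not been measured. It differs from compound 2 in one place: 4-aminophenyl in place of carbamoyl on an aromatic carbon. Going by the values given here, no step between two measured compounds is available, so the size of this change can only be judged from the values shown. Compound 1 also carries a second aromatic ring and gives 5000 nM. On that basis compound 4 is expected to show a step of about an at least 2.0-fold lower number from compound 2 to compound 4 (0.30 log units; that floor lies within the scatter). For compound 4 the estimate is 5000 nM, ranging from 1500 nM to 15000 nM.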

Compound 4, half-maximal inhibitory concentration: 3500 nM
Estimate against measurement, compound 4: 1.4-fold (0.15 log units) above, within the range that was stated.
By their numbers in this assay, from the lowest: compounds 4 and 1 (each within the scatter of the next); then compound 3.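

In this assay, 4-aminophenyl in place of carbamoyl on this aromatic carbon gives an at least 2.8-fold lower number from compound 2 to compound 4 (0.45 log units; beyond the scatter). Going by these compounds alone, this is the first measured step at this position, and it shows that the larger group carrying a second aromatic ring is tolerated here and gives a clearly lower number. The step has only a lower bound, since the value for compound 2 is a limit and not a number: the limit of > 10000 nM in this assay, at which 1 of the 4 values shown sits.

Whether the added ring or its amine accounts for the step stays open. A plain phenyl group at this position would separate the two.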